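Hydroxy on the Phenyl Ring: Cell Tolerance Still Open

The source may hold more compounds than are shown below. What is called first, only, known or untested is meant among the compounds shown, and "the series" means these compounds.

Two measured compounds share one core and differ only in the ring attached to it. Compound 1 `Cc1nc(-c2cnc3ccc(-c4ccc(N)nc4)cc3c2)no1` carries a 6-aminopyridin-3-yl group there, and in a functional assay on RD cells (Homo sapiens) for inhibition, read by luminescence and ATP content, with a stated time of 72 h (a lower number here means that less compound is tolerated, a higher number that more compound is tolerated), compound 1 gives only a limit, > 7400 nM. Compound 2 `Cc1nc(-c2cnc3ccc(-c4ccccc4)cc3c2)no1` carries a plain phenyl in place of that group, and in this assay compound 2 likewise gives only a limit, > 2500 nM. The step that the two limits leave unreadable from compound 1 to compound 2 therefore cannot be sized, since the limit of > 2500 nM in this assay, at which 1 of the 2 values shown sits, and the limit of > 7400 nM in this assay, at which 1 of the 2 values shown sits, are limits rather than numbers. Going by the values given here, compound 2 thus stands at a limit, and the one other value shown is a limit as well.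

Compound 3 `Cc1nc(-c2cnc3ccc(-c4ccc(O)cc4)cc3c2)no1` is compound 2 with a single change: hydroxy in place of hydrogen on an aromatic carbon. Among the compounds with values here, the only measured step touching this part of the molecule, a step that the two limits leave unreadable from compound 1 to compound 2, is unreadable and gives no guide to direction or size. With nothing pointing to a shift beyond the scatter, compound 3 is expected to land close to compound 2 in this assay. The step that the limit leaves unreadable from compound 2 to compound 3 is expected to be small. The estimate for compound 3 is 8000 nM, within a range from 2500 nM to 30000 nM, and most likely reported again only as a limit.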

Compound 3, half-maximal cytotoxic concentration: > 2500 nM
Compound 3 was reported as a limit; the forecaster's own chance of this, stated with the estimate: 70%; the middle value is on the limit's open side.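

Going by these compounds alone, compound 1, compound 2 and compound 3 are all reported only as limits in this assay, and no step between any two of them can be read. The compounds shown leave open the concentration at which each one becomes toxic to the cells, and whether hydroxy on the phenyl ring changes that concentration at all.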